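This account rests on a few compounds, and the source may have more. Where it says the series, first, only, none or still open, it means among the compounds named here.

Measured so far in an ADME assay on microsomes from liver (Homo sapiens) for metabolic stability, read by LC-MS, with a stated time of 15 min (on this read-out higher numbers stand for a more stable compound and lower numbers for a less stable compound), as follows

- compound 1 `CCNC(=O)Nc1sc2ccccc2c1C(=O)N1CCN(C2CCN(C(=O)OC(C)C)CC2)CC1` gives 3%
- compound 2 `CCNC(=O)Nc1sc2ccccc2c1C(=O)N1CCN(C2CCN(C(=O)OC(C)(C)CF)CC2)CC1` gives 3%
- compound 3 `CCNC(=O)Nc1sc2cc(C)ccc2c1C(=O)N1CCN(C2CCN(C(=O)C(C)C)CC2)CC1` gives 77%

Compound 3 stands highest of the three on this assay and lies beyond the scatter above both other compounds. Compound 4 `CCNC(=O)Nc1sc2cc(C)ccc2c1C(=O)N1CCN(C2CCN(C(=O)C(C)(C)CF)CC2)CC1` remains unmeasured. Its difference from compound 3 is fluoromethyl in place of hydrogen on a saturated chain carbon bound to a carbonyl carbon and two saturated chain carbons and this places fluoromethyl in place of hydrogen on a saturated chain carbon bound to a carbonyl carbon and two saturated chain carbons.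

Going by the values given here, one measured step bears on this change. It is no change at the digits printed from compound 1 to compound 2 (within the scatter) with the same group entering on a saturated chain carbon bound to an oxygen next to a carbonyl group and two saturated chain carbons. That step starts and ends at very low values, so it gives only weak guidance for a compound as high as compound 3. Among the compounds with values here, no measured step shows this change starting from a high value.

Within the data shown here, the single precedent therefore leads to no expected change beyond the scatter, and the estimated move is a number 7 percentage points lower from compound 3 to compound 4 (within the scatter) with the uncertainty kept wider on the lower side. For compound 4 the expected value is 70% with an estimated range from 40% to 88%.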

Compound 4, percent of the compound remaining: 84%
Beside the measured number, compound 4's estimate is 14 percentage points below it; measured number inside the range.
By their numbers in this assay, from the lowest: compounds 1 and 2 (each within the scatter of the next); then compounds 3 and 4 (each within the scatter of the next).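

In this assay, the exchange of isopropyl for 1-(fluoromethyl)-1-methylethyl gives a number 7 percentage points higher from compound 3 to compound 4 (within the scatter). Going by these compounds alone, this is the first reading of the change from a high starting value, where a loss would have had room to appear, and on a saturated chain carbon bound to a carbonyl carbon and two saturated chain carbons the fluoromethyl group leaves compound 4 at 84%. The earlier pair sat too low to show much, yet the change now reads alike in both settings: the same change on two cores in this assay, no change at the digits printed (within the scatter) from compound 1 to compound 2 and a number 7 percentage points higher (within the scatter) from compound 3 to compound 4, 7 percentage points apart, within the scatter of two such steps

As far as these compounds go, what a trifluoromethyl, a hydroxymethyl or an amine entering on the same carbon would do in this assay stays open, as does the effect of a longer chain there. Within the data shown here, also open is which structural difference separates the low values of compounds 1 and 2 from the high values of compounds 3 and 4, as these compounds differ in more than one place and no single step links the two pairs.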